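Swapping a Fluorine for Two Hydroxyl Groups

The source may hold more compounds than are shown below. What is called first, only, known or untested is meant among the compounds shown, and "the series" means these compounds.

Two measured compounds share one core and differ only in the aryl ring fixed to a carbon with a double bond to nitrogen. In a functional assay on HCT-116 cells (Homo sapiens) for inhibition, read by MTT assay, with a stated time of 48 h (on this read-out higher numbers stand for weaker inhibition and lower numbers for stronger inhibition), compound 1 `O=C(CSc1nnc(-c2ccncc2)n1-c1ccccc1)N/N=C/c1ccc(F)cc1` gives 7040 nM. Compound 2 `O=C(CSc1nnc(-c2ccncc2)n1-c1ccccc1)N/N=C/c1cccc(F)c1` reaches only the limit of this assay, > 50000 nM, which is a bound rather than a measured number. For the measured compounds named here, the single measured step shows an at least 7.1-fold higher number from compound 1 to compound 2 (0.85 log units; beyond the scatter), a weakening of inhibition, and the limit of > 50000 nM in this assay, at which 1 of the 2 values shown sits, marks where compound 2 sits. Compound 3 `O=C(CSc1nnc(-c2ccncc2)n1-c1ccccc1)N/N=C/c1ccc(O)c(O)c1` changes compound 2 by 3,4-dihydroxyphenyl in place of 3-fluorophenyl on a carbon with a double bond to nitrogen. Going by the values given here, no measured step covers this change; the only step seen concerns the same ring and shows that a change there can move the number well beyond the scatter. Compound 3 is therefore expected to give 20000 nM, with a range from 3000 nM to 50000 nM. The expected step of an at least 2.5-fold lower number from compound 2 to compound 3 (0.39 log units; beyond the scatter) is uncertain, since compound 2 stands at a limit.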

Compound 3, half-maximal inhibitory concentration: 14700 nM
Estimate against measurement, compound 3: 1.4-fold (0.13 log units) above; low and high end bracket the measured number.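

In this assay, the aryl ring on the carbon with a double bond to nitrogen can carry something other than fluorine and still give a measurable number: 3,4-dihydroxyphenyl in place of 3-fluorophenyl brings an at least 3.4-fold lower number from compound 2 to compound 3 (0.53 log units; beyond the scatter). Going by these compounds, the true size of that step stays unknown, because compound 2 has only a limit and not a number: the limit of > 50000 nM in this assay, at which 1 of the 3 values shown sits. Set against 4-fluorophenyl, however, 3,4-dihydroxyphenyl falls short, with a 2.1-fold higher number from compound 1 to compound 3 (0.32 log units; beyond the scatter), so compound 1 remains the strongest of the three.

On these data alone, what a ring with a single hydroxyl group would give remains open. So does the effect of an amine, a carboxylic acid or two methoxy groups on this ring.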